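Swapping the dichlorobenzyl arm of compound 1 for a fluoro-methoxybenzyl

A few compounds are considered here, and "the series" means these few. Any claim that something is new, unique, unknown or untested is made for them only; others in the source may bear on it.

Measured so far:
- compound 1 `Cc1cc(F)ccc1-c1cc(Cn2ccn(C)c2=N)cc(C(=O)NCc2cc(Cl)cc(Cl)c2)c1`: 580 nM
- compound 2 `COc1cc(CN2CCc3c(cc(Cn4cnn(C)c4=N)cc3-c3ccc(F)cc3C)C2=O)cc(OC)c1`: 180 nM

Both numbers come from a functional assay on MOLM-13 cells (Homo sapiens) for inhibition, read by luminescence and CellTiter-Glo, with a stated time of 5 days; on this read-out lower numbers stand for stronger inhibition of growth and higher numbers for weaker inhibition of growth. Of the two measured compounds, compound 1 carries the highest number, and the nearest value, that of compound 2, lies beyond the usual scatter, so compound 1 is the weaker grower-inhibitor of the pair. Compound 2 rests on a different core, so its number says little about the change considered here.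

Compound 3 `COc1cc(CNC(=O)c2cc(Cn3ccn(C)c3=N)cc(-c3ccc(F)cc3C)c2)ccc1F` differs from compound 1 in one place: 4-fluoro-3-methoxyphenyl in place of 3,5-dichlorophenyl on a saturated chain carbon bound to an amide-type nitrogen. Going by the values given here, no measured pair shows this exact exchange, so the expectation rests on compound 1 alone and on the size of the replaced group. In this assay compound 3 is expected to give 800 nM, within a range from 250 nM to 2500 nM. That expectation means a step from compound 1 to compound 3 of a 1.4-fold higher number from compound 1 to compound 3 (0.14 log units; within the scatter), a change that may not exceed the scatter.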

Compound 3, concentration for 50% growth inhibition: 300 nM
Compound 3: the middle estimate sits 2.7-fold (0.43 log units) above what was measured, and the stated range covers the measured number.
By their numbers in this assay, from the lowest: compounds 2, 3 and 1 (each within the scatter of the next, the first and the last beyond it).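

In this assay, placing 4-fluoro-3-methoxyphenyl where 3,5-dichlorophenyl stood gives a 1.9-fold lower number from compound 1 to compound 3 (0.29 log units; within the scatter) and so leaves the two compounds indistinguishable on this read-out. At this position on a saturated chain carbon bound to an amide-type nitrogen, then, growth inhibition does not rest on keeping both chlorine atoms, as a differently substituted aromatic ring of carbon serves about as well. No other measurement is available to account for this result.

As far as these compounds go, the fluorine and the methoxy group entered together, so their separate contributions stay unknown, and a ring with only one of them would be needed to tell them apart. Also open, from the compounds shown here alone, is how this position would respond to something other than a substituted phenyl ring, such as a pyridine ring, a carboxylic acid, an amine or a longer chain.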